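Series notes: from compound 1 to compound 4

This account rests on a few compounds, and the source may have more. Where it says the series, first, only, none or still open, it means among the compounds named here.

Measured so far in a functional assay on HeLa cells (Homo sapiens) for antiproliferative activity, read by CCK-8 assay, with a stated time of 72 h, tested at 8 uM; on this read-out higher numbers stand for a stronger effect at the one concentration tested and lower numbers for a weaker effect:
compound 1, `Nc1ccccc1NC(=O)c1ccc(CSC(=S)N2CCN(Cc3ccncc3)CC2)cc1`, where compound 1 gives 72.9%
compound 2, `Nc1ccccc1NC(=O)c1ccc(CSC(=S)N2CCCc3ccccc32)cc1`, where compound 2 gives 35.7%
compound 3, `Nc1ccccc1NC(=O)c1ccc(CSC(=S)N2CCc3cc(Cl)ccc32)cc1`, where compound 3 gives 65.1%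

Compound 1 holds the highest of the three numbers; compound 3 lies within the scatter of it, compound 2 beyond it. Going by the values given here, the one single-change step known is a number 29.4 percentage points higher from compound 2 to compound 3 (beyond the scatter), a swap of the group on the thiocarbonyl carbon. Compound 4, `Cc1ccc(N2CCN(C(=S)SCc3ccc(C(=O)Nc4ccccc4N)cc3)CC2)cc1`, differs from compound 1 at another place: 4-methylphenyl in place of (pyridin-4-yl)methyl on an amine nitrogen in a ring. Among the compounds with values here, no measured step touches that ring nitrogen, so the move from compound 1 to compound 4 has no direct comparison, and nothing in hand points to a shift beyond the scatter. The step of a number 8.9 percentage points lower from compound 1 to compound 4 (within the scatter) is expected to stay within the scatter. The estimate for compound 4 in this assay is 64%, within 46% to 80%.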

Compound 4, a percentage reported as inhibition, at one concentration (the size of the read-out at that concentration, not a potency): 24%
The estimate for compound 4 lay 40 percentage points above the measured number, outside the stated range (below it).
By their numbers in this assay, from the lowest: compound 4; then compound 2; then compounds 3 and 1 (each within the scatter of the next).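

Substitution on the amine nitrogen in the ring is not neutral in this assay: 4-methylphenyl in place of (pyridin-4-yl)methyl gives a number 48.9 percentage points lower from compound 1 to compound 4 (beyond the scatter) on this shared core. Both groups hold 7 heavy atoms and one six-membered aromatic ring, but only the leaving group has a ring nitrogen and a hydrogen-bond acceptor. No evidence on the origin of this step is at hand.

Still open, from the compounds shown here alone, is whether the ring nitrogen of the pyridine or the methylene link matters more; 4-methylbenzyl and pyridin-4-yl on the same amine nitrogen would separate the two.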